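An Oxolanylmethyl Group in Place of Isopropyl

A few compounds are considered here, and "the series" means these few. Any claim that something is new, unique, unknown or untested is made for them only; others in the source may bear on it.

Measured in an ADME assay on liver (Mus musculus, strain CD-1) for metabolic stability, read by LC-MS, using microsomes and NADPH, with a stated time of 5 min, tested at 1 uM; on this read-out higher numbers stand for a longer-lived compound and lower numbers for a shorter-lived compound:
compound 1 `COc1ccc(NC(=O)C(=O)c2cn(C(C)C)c3ccccc23)cn1`: 0.0833 h
compound 2 `COc1ccc(NC(=O)C(=O)c2cc(C(C)C)n3ccccc23)cn1`: < 0.0834 h, which is a limit of the assay and not a number

Compound 1 holds the only number shown in this assay; the other value is a limit, (the limit of < 0.0834 h in this assay, at which 1 of the 2 values shown sits). Compound 3 `COc1ccc(NC(=O)C(=O)c2cn(CC3CCCO3)c3ccccc23)cn1` carries (oxolan-2-yl)methyl in place of isopropyl on an aromatic nitrogen. No step between measured compounds exists here, so the shown values say nothing about how this change affects this assay. The step from compound 1 to compound 3 is expected to stay within the scatter, a 1.1-fold higher number from compound 1 to compound 3 (0.03 log units; within the scatter). Compound 3 is therefore estimated at 0.09 h, between 0.04 h and 0.25 h.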

Compound 3, half-life: 0.567 h
The estimate for compound 3 lay 6.3-fold (0.80 log units) below the measured number; the whole stated range lies below it.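

In this assay, the position on the aromatic nitrogen proves sensitive to its substituent: (oxolan-2-yl)methyl in place of isopropyl gives a 6.8-fold higher number from compound 1 to compound 3 (0.83 log units; beyond the scatter). For the compounds shown here, this is the first readable step at this position, and it shows that isopropyl is not required there for a measurable half-life. Nothing shown accounts for the rise.

As far as these compounds go, whether the ring or its oxygen drives the step stays open, as does how a cyclopentylmethyl group or a 2-methoxyethyl chain would read here. From the compounds shown here alone, the same exchange on compound 2, whose < 0.0834 h is a limit of the assay and not a number, also remains open.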